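Changing the Heterocycle on the Sulfonamide Nitrogen

The source may report more compounds than this note shows. Statements on the series, on what has been measured and on what is new or still open speak of the compounds shown alone.

Compound 1, `Cc1cc(NS(=O)(=O)c2ccc(N/C(S)=N\c3ccnc4cc(C(F)(F)F)ccc34)cc2)on1`: 28500 nM
Compound 2, `O=S(=O)(Nc1ncccn1)c1ccc(N/C(S)=N\c2ccnc3cc(C(F)(F)F)ccc23)cc1`: 42100 nM
Compound 3, `Cc1cc(C)nc(NS(=O)(=O)c2ccc(N/C(S)=N\c3ccnc4cc(C(F)(F)F)ccc34)cc2)n1`: 72200 nM

All three compounds share the same core and differ only in the aromatic ring attached to the sulfonamide nitrogen. In a functional assay on HepG2 cells (Homo sapiens) for antiproliferative activity, read by sulforhodamine B assay, with a stated time of 48 h (a higher number here means a weaker inhibitor, a lower number a stronger inhibitor), compound 3 stands at the highest number of the three. The step of a 1.7-fold higher number from compound 2 to compound 3 (0.23 log units; within the scatter) lies within the scatter, so the two cannot be ranked against each other, whereas the step of a 2.5-fold higher number from compound 1 to compound 3 (0.40 log units; beyond the scatter) is beyond the scatter and counts as a modest weakening.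

Compound 4, `COc1cc(NS(=O)(=O)c2ccc(N/C(S)=N\c3ccnc4cc(C(F)(F)F)ccc34)cc2)nc(OC)n1`, is not yet measured. It changes the same position once more: 2,6-dimethoxypyrimidin-4-yl in place of 4,6-dimethylpyrimidin-2-yl on a sulfonamide nitrogen. The three measured steps all concern this ring, and they were small: a 1.5-fold higher number from compound 1 to compound 2 (0.17 log units; within the scatter), a 2.5-fold higher number from compound 1 to compound 3 (0.40 log units; beyond the scatter) and a 1.7-fold higher number from compound 2 to compound 3 (0.23 log units; within the scatter). None of them involves a methoxy-bearing ring, so there is no direct guide for the new group. Given how little this position has moved so far, the expected step from compound 3 is a 1.1-fold lower number from compound 3 to compound 4 (0.05 log units; within the scatter), that is, nothing beyond the scatter in either direction. For compound 4 the estimate is therefore 65000 nM, with a range from 25000 nM to 170000 nM.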

Compound 4, half-maximal inhibitory concentration: 76700 nM
Estimate against measurement, compound 4: 1.2-fold (0.07 log units) below, and the stated range covers the measured number.
By their numbers in this assay, from the lowest: compounds 1, 2, 3 and 4 (each within the scatter of the next, the first and the last beyond it).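

In this assay the swap to 2,6-dimethoxypyrimidin-4-yl gives a 1.1-fold higher number from compound 3 to compound 4 (0.03 log units; within the scatter) and so cannot be told apart from the group it replaces, which shows that this position also tolerates a larger ring, the only methoxy-bearing one among the four compounds, with more heavy atoms and more hydrogen-bond acceptors and no clear change in the number. Compared with the two remaining rings, the result follows the pattern of compound 3: a 1.8-fold higher number from compound 2 to compound 4 (0.26 log units; within the scatter) is again no separable difference, while a 2.7-fold higher number from compound 1 to compound 4 (0.43 log units; beyond the scatter) is a modest weakening, so the 3-methyl-1,2-oxazol-5-yl compound now stands apart from two of the pyrimidine compounds rather than one. No measured property of these rings is available to explain where their numbers fall.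

On these data alone, the methoxy groups and the shift from a 2-yl to a 4-yl attachment arrive together in compound 4, so their separate contributions remain unknown. As far as these compounds go, all four groups are aromatic rings with no charge, so it remains open how this position would respond to a ring carrying an amine or a carboxylic acid, or to a plain alkyl chain.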